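1,3-Thiazol-5-yl to thiophen-2-yl: working notes

The source may report more compounds than this note shows. Statements on the series, on what has been measured and on what is new or still open speak of the compounds shown alone.

Measured in an in vitro ADME assay on microsomes from liver (Homo sapiens) for metabolic stability; on this read-out lower numbers stand for slow clearance and higher numbers for fast clearance:
- compound 1 `O=C(COCc1ccncn1)N1CCN(c2ccc(Cl)cc2Cl)CC1`: 17 mL.min-1.g-1
- compound 2 `O=C(COCc1cncs1)N1CCN(c2ccc(Cl)cc2Cl)CC1`: 73 mL.min-1.g-1

Of these two, compound 2 has the higher number, at 73 mL.min-1.g-1. Compound 3 `O=C(COCc1cccs1)N1CCN(c2ccc(Cl)cc2Cl)CC1` is not yet measured and differs from compound 2 as follows: thiophen-2-yl in place of 1,3-thiazol-5-yl on a saturated chain carbon bound to an oxygen on a saturated carbon. Among the measured compounds shown here, one measured step bears on this change, the exchange of one aromatic ring for another at the same place: a 4.3-fold higher number from compound 1 to compound 2 (0.63 log units; beyond the scatter), which is modest and beyond the scatter. A single step is a thin guide, so a modest rise in this assay is expected, at most of similar size, a 1.5-fold higher number from compound 2 to compound 3 (0.18 log units; within the scatter). The expected value for compound 3 is 110 mL.min-1.g-1, with an estimated range of 55 mL.min-1.g-1 to 220 mL.min-1.g-1.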

Compound 3, intrinsic clearance in microsomes: 360 mL.min-1.g-1
Compound 3: the middle estimate sits 3.3-fold (0.51 log units) below what was measured, and the stated range ends below it.
By their numbers in this assay, from the lowest: compound 1; then compound 2; then compound 3.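

In this assay, the ring on the saturated chain carbon bound to an oxygen on a saturated carbon proves a strong handle: thiophen-2-yl in place of 1,3-thiazol-5-yl gives (a 4.9-fold higher number from compound 2 to compound 3 (0.69 log units; beyond the scatter)), and thiophen-2-yl in place of pyrimidin-4-yl gives (a 21-fold higher number from compound 1 to compound 3 (1.33 log units; beyond the scatter)). A second ring exchange at this place thus raises the number again, and thiophen-2-yl, with one hetero atom, carries the highest value of the three. Nothing available accounts for these steps.

On these data alone, whether a plain phenyl ring at this place follows thiophen-2-yl remains open. So does whether a carboxylic acid on the thiophen-2-yl ring would bring the number back down.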